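The source may report more compounds than this note shows. Statements on the series, on what has been measured and on what is new or still open speak of the compounds shown alone.

Of the compounds shown here, three on a shared core have been measured: compound 3 `COc1ccc2c(/C=C(\C#N)C(=O)c3c[nH]c4ccccc34)c[nH]c2c1`, compound 1 `COc1ccc2c(/C=C(\C#N)C(=O)c3c[nH]c4cc(OC)ccc34)c[nH]c2c1` and compound 2 `N#C/C(=C\c1c[nH]c2cc(F)ccc12)C(=O)c1c[nH]c2ccccc12`, and the set extends to the still unmeasured compound 4 `COc1ccc2[nH]cc(C(=O)/C(C#N)=C/c3c[nH]c4cc(F)ccc34)c2c1`. Cytotoxicity was read in a functional assay on MIA PaCa-2 cells (Homo sapiens) for cytotoxicity, read by WST assay, with a stated time of 48 h; a lower number here means a stronger inhibitor, a higher number a weaker inhibitor. Compound 3 gives > 50000 nM, which is a limit of the assay and not a number. Compound 1 gives > 50000 nM, again a limit. The change from compound 3 to compound 1 is methoxy in place of hydrogen on an aromatic carbon, and its step, a step that the two limits leave unreadable from compound 3 to compound 1, cannot be read because of the limit of > 50000 nM in this assay, at which 2 of the 3 values shown sit. Within the data shown here, compound 2 differs from compound 3 by fluoro in place of methoxy on an aromatic carbon; in this assay compound 2 gives 31600 nM, the only full number in the set, and from it follows the step of an at least 1.5-fold higher number from compound 2 to compound 3 (0.19 log units; that floor lies within the scatter). Among the measured compounds shown here, compound 4 carries the same change as the one from compound 3 to compound 1, namely (methoxy in place of hydrogen on an aromatic carbon), at the same place. Where that change was measured it gave no readable step, so the expectation rests mainly on compound 2 at 31600 nM. Compound 4 is therefore expected to give about 40000 nM in this assay, with a range from 15000 nM to 120000 nM. That corresponds to an expected step of a 1.3-fold higher number from compound 2 to compound 4 (0.10 log units; within the scatter).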

Compound 4, half-maximal inhibitory concentration: > 50000 nM
Compound 4 gave a limit, no number (the forecaster's own chance of this, stated with the estimate: 45%); middle value at least 1.2-fold (0.09 log units) from the limit.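

On the core of compound 2, methoxy in place of hydrogen on an aromatic carbon gives an at least 1.5-fold higher number from compound 2 to compound 4 (0.19 log units; that floor lies within the scatter) in this assay, so this change does not yield a step shown to lie beyond the scatter on that core. Among these compounds, the same change from compound 3 to compound 1 cannot be read, so the series offers no pair of sizes to set side by side, and it cannot be said whether the change carries over from one core to the other. The full size of the step is unknown on both cores because the values stop at a limit: the limit of > 50000 nM in this assay, at which 3 of the 4 values shown sit.

Compound 2 gives 31600 nM, the only full number shown, so the compounds leave open which changes to this core would lower that number in this assay. Going by these compounds, whether an amine, a carboxylic acid or a longer chain such as ethoxy at the same place would give a full number also remains open.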